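A few compounds are considered here, and "the series" means these few. Any claim that something is new, unique, unknown or untested is made for them only; others in the source may bear on it.

In a functional assay on MCF7 cells (Homo sapiens) for cytotoxicity, read by MTT assay, with a stated time of 4 days (on this read-out lower numbers stand for stronger inhibition and higher numbers for weaker inhibition), a small set of closely related compounds was tested. Compound 1, with the structure `C=C1C[C@]23C[C@@]1(O)CC[C@H]2c1ccc(O)c(C)c1[C@@H]3Cn1cc(-c2ccccn2)nn1`, carries a pyridin-2-yl group on a five-membered aromatic ring with three nitrogens. In this assay compound 1 gives only a limit, > 20000 nM, and no number. Compound 2, `C=C1C[C@]23C[C@@]1(O)CC[C@H]2c1ccc(O)c(C)c1[C@@H]3Cn1cc(-c2ccc(C(F)(F)F)cc2)nn1`, differs from compound 1 by a single change, (4-(trifluoromethyl)phenyl in place of pyridin-2-yl on an aromatic carbon). In this assay compound 2 gives 12400 nM. The step of an at least 1.6-fold lower number from compound 1 to compound 2 (0.20 log units; that floor lies within the scatter) is therefore known only as a floor, not as a full size.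

Compound 3, `Cc1c(O)ccc2c1[C@H](Cn1cc(-c3ccccn3)nn1)[C@@]13CC(=O)[C@@](C)(CC[C@@H]21)C3`, is built on a different core; how its core differs from the core of compound 1 is not broken down here. In this assay compound 3 gives only a limit, > 20000 nM. Compound 4, `Cc1c(O)ccc2c1[C@H](Cn1cc(-c3ccc(C(F)(F)F)cc3)nn1)[C@@]13CC(=O)[C@@](C)(CC[C@@H]21)C3`, has not yet been measured. It stands to compound 3 exactly as compound 2 stands to compound 1, the same change: 4-(trifluoromethyl)phenyl in place of pyridin-2-yl on an aromatic carbon.

Any expectation here rests on thin ground, since the limit of > 20000 nM in this assay, at which 2 of the 3 values shown sit, means that two of the three measured compounds show no number at all. For the measured compounds named here, the one measured step, an at least 1.6-fold lower number from compound 1 to compound 2 (0.20 log units; that floor lies within the scatter), carried compound 2 to a measured number. The expected step of an at least 1.3-fold lower number from compound 3 to compound 4 (0.12 log units; that floor lies within the scatter) is taken to be of similar size. Compound 4 is therefore expected to come out near 15000 nM, estimated between 7000 nM and 35000 nM, with a fair chance that only a limit is reported.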

Compound 4, half-maximal inhibitory concentration: > 20000 nM
Compound 4 ended at the assay's limit (the forecaster's own chance of this, stated with the estimate: 50%); at least 1.3-fold (0.12 log units) between middle value and limit.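

No size can be read for the change from compound 3 to compound 4, because both compounds give only a limit and no number: the limit of > 20000 nM in this assay, at which 3 of the 4 values shown sit. The compounds shown leave open whether 4-(trifluoromethyl)phenyl in place of pyridin-2-yl lowers the number at all on the core of compound 3, and how large the same change really is on the core of compound 1.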